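Adenosine receptor A3 ureas: benzyl against phenyl on the urea

The source may report more compounds than this note shows. Statements on the series, on what has been measured and on what is new or still open speak of the compounds shown alone.

Measured compounds:
- compound 1, `O=C(NCc1ccccc1)Nc1nn(-c2ccccc2)c(=O)c2ccccc12`, 29.6 nM
- compound 2, `O=C(Nc1ccccc1)Nc1nn(-c2ccccc2)c(=O)c2ccccc12`, 178 nM

Both compounds share one core and differ only at the urea nitrogen remote from that core. In an assay on CHO cells for displacement of a labelled ligand from adenosine receptor A3 (Homo sapiens) (a higher number here means a weaker inhibitor, a lower number a stronger inhibitor), compound 1 gives 29.6 nM, while compound 2 gives 178 nM. Within the data shown here, the one step between them, a 6.0-fold higher number from compound 1 to compound 2 (0.78 log units; beyond the scatter), is the only comparison available. Compound 2 therefore stands at the highest number of the two.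

Compound 3, `COc1ccccc1CNC(=O)Nc1nn(-c2ccccc2)c(=O)c2ccccc12`, is not yet measured. Relative to compound 2 the change is 2-methoxybenzyl in place of phenyl on an amide-type nitrogen. This change largely reverses the step from compound 1 to compound 2: a benzyl-type group returns to the urea nitrogen, now carrying a methoxy group. Among the measured compounds shown here, the sole step that bears on it is a 6.0-fold higher number from compound 1 to compound 2 (0.78 log units; beyond the scatter), and the expectation is that most of it is undone in this assay. For compound 3 a step of a 5.1-fold lower number from compound 2 to compound 3 (0.71 log units; beyond the scatter) is expected, and its value in this assay is estimated at 35 nM, with a range from 12 nM to 110 nM.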

Compound 3, inhibition constant: 274 nM
Compound 3: middle estimate off by 7.8-fold (0.89 log units), on the low side; the measured number lies above the stated range.
By their numbers in this assay, from the lowest: compound 1; then compounds 2 and 3 (each within the scatter of the next).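

In this assay, a benzyl-type group on the amide-type nitrogen does not by itself keep the lower number: the step of a 1.5-fold higher number from compound 2 to compound 3 (0.19 log units; within the scatter) leaves compound 3 indistinguishable from compound 2 despite the change from phenyl to 2-methoxybenzyl. The change that matters here is methoxy in place of hydrogen on an aromatic carbon, with a 9.3-fold higher number from compound 1 to compound 3 (0.97 log units; beyond the scatter) as its size, so this position does not tolerate every benzyl-type group equally. Nothing available explains this result.

Only one substituted benzyl is shown, so it remains open whether the loss belongs to methoxy specifically or would also follow another group at that place, such as hydroxy or chlorine. Also open, going by these compounds, is how a longer chain, such as phenethyl, would read on the same nitrogen.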